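Swapping the aryl ether for a methoxypyridinylmethyl ether

The source may hold more compounds than are shown below. What is called first, only, known or untested is meant among the compounds shown, and "the series" means these compounds.

Compound 2 `Cc1cc(Oc2ccc(-c3ccn4c(CC5CC5)nnc4c3C(F)(F)F)cc2F)ccn1` gives 7.08 nM in an assay on cells for displacement of a labelled ligand from metabotropic glutamate receptor 2 (Homo sapiens), read by scintillation counting, with a stated time of 60 min (on this read-out lower numbers stand for stronger inhibition and higher numbers for weaker inhibition), the lower of the two numbers in hand. Compound 1 `Cc1cc(Oc2ccc(-c3ccn4c(CC5CC5)nnc4c3Cl)cc2F)ccn1` gives 63.1 nM in this assay, and the step of an 8.9-fold lower number from compound 1 to compound 2 (0.95 log units; beyond the scatter) came with trifluoromethyl in place of chloro on an aromatic carbon. Compound 3 `COc1ccc(COc2ccc(-c3ccn4c(CC5CC5)nnc4c3C(F)(F)F)cc2F)cn1` keeps that trifluoromethyl and differs from compound 2 only in (6-methoxypyridin-3-yl)methyl in place of 2-methylpyridin-4-yl on an oxygen on an aromatic ring. Within the data shown here, no measured step touches this part of the molecule: the single step in hand, from compound 1 to compound 2, concerns a different place, so it gives no direct guide to the direction or size of the change. The group that enters is larger and carries one more acceptor, and the link to the oxygen on the aromatic ring changes from an aromatic carbon to a methylene. Compound 3 is therefore expected to show a 2.1-fold higher number from compound 2 to compound 3 (0.33 log units; beyond the scatter), with wide uncertainty, and its estimated value in this assay is 15 nM, within 3 nM to 80 nM.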

Compound 3, inhibition constant: 11.8 nM
Estimate against measurement, compound 3: 1.3-fold (0.10 log units) above; the measured number falls inside the stated range.
By their numbers in this assay, from the lowest: compounds 2 and 3 (each within the scatter of the next); then compound 1.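

Among these compounds, the step of a 1.7-fold higher number from compound 2 to compound 3 (0.22 log units; within the scatter) is the first reading at this position, on an oxygen on an aromatic ring, and it lies within the scatter, so the two compounds cannot be told apart in this assay on this evidence. With the trifluoromethyl kept, the read-out therefore holds when (6-methoxypyridin-3-yl)methyl, the larger group with its methylene link, replaces 2-methylpyridin-4-yl. Nothing in hand offers an explanation for this result.

The methylene and the methoxy enter together, so the compounds shown do not separate what each contributes. Also open, as far as these compounds go, is how a longer chain in place of the methylene, or an amine in place of the methoxy, would read in this assay, and whether the same ether would hold with chloro in place of trifluoromethyl.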